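The source may hold more compounds than are shown below. What is called first, only, known or untested is meant among the compounds shown, and "the series" means these compounds.

Of the compounds shown here, three built on one shared core have so far been tested in a functional assay on Huh-7 cells (Homo sapiens), read by fluorescence and BrdU incorporation, with a stated time of 48 h, tested at 10 uM; on this read-out higher numbers stand for a weaker effect at the one concentration tested and lower numbers for a stronger effect. Compound 1 `COc1cc(OC)c(C(=O)/C=C/c2ccccc2SC)c(OC)c1` gives 37%. Compound 2 `COc1cc(OC)c(C(=O)/C=C/c2ccccc2)c(OC)c1` gives 45%. Compound 3 `COc1cc(OC)c(C(=O)/C=C/c2ccc(Cl)cc2)c(OC)c1` gives 33%. The steps between them are small: a number 8 percentage points higher from compound 1 to compound 2 (within the scatter), a number 4 percentage points lower from compound 1 to compound 3 (within the scatter), and a number 12 percentage points lower from compound 2 to compound 3 (beyond the scatter). On these three numbers compound 3 stands lowest; compound 1 sits nearest to it, within the scatter, and compound 2 sits furthest, beyond the scatter.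

Compound 4 `COc1cc(OC)c(C(=O)/C=C/c2ccc(F)cc2)c(OC)c1` has not yet been tested. Its difference from compound 3 is fluoro in place of chloro on an aromatic carbon: chloro leaves and fluoro enters, on an aromatic carbon of a six-membered aromatic ring of carbon only, para to a large group. Among the compounds with values here, the one measured step that bears on this place is a number 12 percentage points lower from compound 2 to compound 3 (beyond the scatter), where a halogen was added to that carbon. Swapping one halogen for another at the same carbon is a smaller change than adding one, so the step of a number 5 percentage points higher from compound 3 to compound 4 (within the scatter) is expected to stay within the scatter, with compound 4 expected to land close to compound 3 or slightly toward compound 2. In this assay compound 4 is therefore estimated at 38%, with a range from 28% to 50%.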

Compound 4, a percentage reported as activity, at one concentration (the size of the read-out at that concentration, not a potency): 44%
The estimate for compound 4 lay 6 percentage points below the measured number; the measured number falls inside the stated range.
By their numbers in this assay, from the lowest: compounds 3, 1, 4 and 2 (each within the scatter of the next, the first and the last beyond it).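

This result shows that the two halogens cannot be treated as interchangeable at this carbon of the six-membered aromatic ring, para to a large group, in this assay (with a number 11 percentage points higher from compound 3 to compound 4 (beyond the scatter)). Adding a halogen there is therefore not enough on its own: chloro gave a step beyond the scatter (with a number 12 percentage points lower from compound 2 to compound 3 (beyond the scatter)), whereas fluoro gives a step within it (with a number 1 percentage points lower from compound 2 to compound 4 (within the scatter)), and the step that replaces the whole 2-(methylsulfanyl)phenyl group with 4-fluorophenyl also stays within the scatter (with a number 7 percentage points higher from compound 1 to compound 4 (within the scatter)). Nothing shown here explains why chloro and fluoro part ways at this carbon.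

Going by these compounds, whether bromo, a methoxy group, an amine or a carboxylic acid at this same carbon would give a number close to that of compound 3 or close to that of compound 2 remains open. Each number also comes from a single concentration, so how these compounds would compare across a range of concentrations is open as well.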